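The compounds below may be only part of what the source reports. "The series", "measured", "known", "first", "only" and "open" are said of these compounds alone.

Compound 1, `O=C(N/N=C/c1ccccc1)c1cnccn1`, gives 75%.
Compound 2, `O=C(N/N=C/c1ccc(Cl)cc1)c1cnccn1`, gives 64%.
Compound 3, `O=C(N/N=C/c1cccc(Br)c1)c1cnccn1`, gives 100%.

These numbers come from an ADME assay on J774 cells (Mus musculus) for cytotoxicity, read by MTT assay, with a stated time of 48 h, tested at 100 ug/mL; a lower number here means a stronger effect, a higher number a weaker effect of the compound at the concentration tested. Compound 3 stands highest of the three, meaning the weakest effect; compound 1 is its nearest neighbour and compound 2 lies furthest below it. Compound 4, `N#Cc1cccc(/C=N/NC(=O)c2cnccn2)c1`, is not yet measured and differs from compound 3 in one place: cyano in place of bromo on an aromatic carbon. For the measured compounds named here, no measured step swaps a cyano for a bromo. The two known steps both start from compound 1: a number 11 percentage points lower from compound 1 to compound 2 (beyond the scatter) and a number 25 percentage points higher from compound 1 to compound 3 (beyond the scatter), so a halogen moved the number modestly in either direction. Taking the bromo away could undo the rise seen in a number 25 percentage points higher from compound 1 to compound 3 (beyond the scatter), though a cyano is untested here. Compound 4 is therefore expected to sit a little lower, a step of a number 20 percentage points lower from compound 3 to compound 4 (beyond the scatter). The estimate for compound 4 is 80%, within a range of 55% to 100%.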

Compound 4, a percentage reported as activity, at one concentration (the size of the read-out at that concentration, not a potency): 100%
Compound 4: the middle estimate sits 20 percentage points below what was measured, within the range that was stated.
By their numbers in this assay, from the lowest: compound 2; then compound 1; then compounds 3 and 4 (each within the scatter of the next).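

In this assay cyano in place of bromo gives no change at the digits printed from compound 3 to compound 4 (within the scatter) so at this position the two groups cannot be told apart by this read-out. Set against hydrogen, cyano gives a number 25 percentage points higher from compound 1 to compound 4 (beyond the scatter) so the rise seen at this place does not belong to bromo alone. Nothing measured here explains why these two different groups give the same number.

As far as these compounds go, whether an amine or a carboxylic acid at this place would also hold the number up remains open. So does whether cyano would behave the same where compound 2 carries its chloro.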